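Fluoro to Chloro on the Urea Aryl Ring

A few compounds are considered here, and "the series" means these few. Any claim that something is new, unique, unknown or untested is made for them only; others in the source may bear on it.

Of the compounds shown here, two have been measured in a functional assay on NCI-H460 cells (Homo sapiens) for cytotoxicity, read by MTT assay, with a stated time of 72 h; a higher number here means a weaker inhibitor, a lower number a stronger inhibitor. Compound 1, `CN(C)CCCNc1nc(-c2ccc(NC(=O)Nc3ccccc3Cl)cc2)nc2ccsc12`, gives 430 nM in this assay. Compound 2, `CN(C)CCNc1nc(-c2ccc(NC(=O)Nc3ccccc3F)cc2)nc2ccsc12`, gives 410 nM in this assay. Compound 2 stands with the lowest of the two numbers shown, but compound 1 lies within the scatter of it, so the two are not distinguished. Going by the values given here, no single-point step between the two measured compounds is available, as they differ in both the chain and the halogen.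

Compound 3, `CN(C)CCNc1nc(-c2ccc(NC(=O)Nc3ccccc3Cl)cc2)nc2ccsc12`, is not yet measured. It departs from compound 2 by chloro in place of fluoro on an aromatic carbon. Among the compounds with values here, the data give no measured step for this exchange alone, and the two measured compounds, which carry the two halogens on different chains, show values within the scatter of each other. Compound 3 is therefore expected to show no step beyond the scatter, a 1.0-fold lower number from compound 2 to compound 3 (0.01 log units; within the scatter). The estimate for compound 3 in this assay is 400 nM, with a range from 200 nM to 800 nM.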

Compound 3, half-maximal inhibitory concentration: 230 nM
Estimate against measurement, compound 3: 1.7-fold (0.24 log units) above; low and high end bracket the measured number.
By their numbers in this assay, from the lowest: compounds 3, 2 and 1 (each within the scatter of the next).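

In this assay, the exchange of 2-fluorophenyl for 2-chlorophenyl can now be read alone, with the chain held constant, and it amounts to a 1.8-fold lower number from compound 2 to compound 3 (0.25 log units; within the scatter). Chloro in place of fluoro at this place, on an aromatic carbon and ortho to a large group, therefore gives no step beyond the scatter, and the same holds for the chain with the 2-chlorophenyl group held constant, where dimethylamino in place of (dimethylamino)methyl gives a 1.9-fold lower number from compound 1 to compound 3 (0.27 log units; within the scatter), so neither single change separates these compounds. No measurement here bears on why the values fall as they do.

The compounds shown leave open whether a larger or different group at this place, such as bromo, methyl, methoxy or trifluoromethyl, would give a step beyond the scatter, and whether the halogen would read the same on another carbon of the phenyl ring. They also leave open how a longer chain, or a morpholine or piperidine in place of the dimethylamino end, would read in this assay, where the two changes seen so far stay within the scatter.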